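A sulfur-bearing ring in place of piperidine on the core

The source may hold more compounds than are shown below. What is called first, only, known or untested is meant among the compounds shown, and "the series" means these compounds.

compound 1 `N[C@H]1CC[C@H](Nc2c(C(=O)NCc3ccc(F)cc3)nc(N3CCCCC3)c3cccnc23)CC1`: 8500 nM
compound 2 `COC(=O)CNc1c(C(=O)NCc2ccc(F)cc2)nc(Br)c2cccnc12`: > 10000 nM
compound 3 `O=C(NCCCNc1c(C(=O)NCc2ccc(F)cc2)nc(Br)c2cccnc12)c1ccccc1`: > 10000 nM

Among the measured compounds shown here, in a functional assay on HCT-116 cells (Homo sapiens) for cytotoxicity, read by MTT assay, with a stated time of 72 h (on this read-out lower numbers stand for stronger inhibition and higher numbers for weaker inhibition), compound 1 gives 8500 nM, the only number among the three values shown. Compound 2 gives a limit of the assay, > 10000 nM. Compound 3 likewise gives only a limit, > 10000 nM. The step that the two limits leave unreadable from compound 2 to compound 3 cannot be read, and the limit of > 10000 nM in this assay, at which 2 of the 3 values shown sit, marks where two of the three values sit. Compound 4 `N[C@H]1CC[C@H](Nc2c(C(=O)NCc3ccc(F)cc3)nc(N3CCCCS3(=O)=O)c3cccnc23)CC1` differs from compound 1 by a group of 8 heavy atoms (4 carbon, 1 nitrogen, 2 oxygen, 1 sulfur; one six-membered non-aromatic ring with 2 hetero atoms) in place of a group of 6 heavy atoms (5 carbon, 1 nitrogen; one six-membered non-aromatic ring with 1 hetero atom), on an aromatic carbon. No measured step touches this carbon of the shared core, so nothing shown points in either direction. Compound 4 is therefore expected to land close to compound 1. The step of a 1.2-fold higher number from compound 1 to compound 4 (0.07 log units; within the scatter) is expected to stay within the scatter. The estimate for compound 4 is 10000 nM, between 3000 nM and 30000 nM.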

Compound 4, half-maximal inhibitory concentration: > 10000 nM
Compound 4 ended at the assay's limit; the forecaster's own chance of this, stated with the estimate: 45%; the middle value sits exactly at the limit.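

In this assay, among the compounds shown here, the sulfur-bearing ring in place of piperidin-1-yl on this aromatic carbon gives an at least 1.1-fold higher number from compound 1 to compound 4 (0.07 log units; that floor lies within the scatter) and is the first step read at this place. The value of compound 4 is a limit, so that step is only a floor, and the change brought no lower number than that of compound 1. Compound 4 joins the compounds that give only a limit: the limit of > 10000 nM in this assay, at which 3 of the 4 values shown sit. From the compounds shown here alone, how far compound 4 lies past that limit stays open. So does whether a morpholine or a piperazine on this carbon would lower the number.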